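This account rests on a few compounds, and the source may have more. Where it says the series, first, only, none or still open, it means among the compounds named here.

In a functional assay on HL-60 cells (Homo sapiens) for antiproliferative activity, read by MTT assay, with a stated time of 48 h (a higher number here means a weaker inhibitor, a lower number a stronger inhibitor), compound 1 `NC(=O)C[C@H](NC(=O)c1cc2ccccc2cn1)C(=O)OCc1ccccc1` gives 86.9 nM and compound 3 `CC[C@@H](C)[C@H](NC(=O)c1cc2ccccc2cn1)C(=O)OCc1ccccc1` gives 96.4 nM. Compound 2 `CSCC[C@H](NC(=O)c1cc2ccccc2cn1)C(=O)OCc1ccccc1`, which shares their core, gives 44.9 nM, placing it at the low end of these three numbers.

Compound 4 `O=C(N[C@@H](CO)C(=O)OCc1ccccc1)c1cc2ccccc2cn1` has not yet been measured. It differs from compound 2 in a single change, with hydroxy in place of (methylsulfanyl)methyl on a saturated chain carbon, two bonds along the chain from an amide-type nitrogen and a carbonyl carbon.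

Among the measured compounds shown here, no measured step makes exactly this exchange, so the closest guides are the two steps that alter the same chain of compound 2. The first is a 1.9-fold lower number from compound 1 to compound 2 (0.29 log units; within the scatter), which stays within the scatter. The second is a 2.1-fold higher number from compound 2 to compound 3 (0.33 log units; beyond the scatter), which only just goes beyond it. Both steps are small, so changes at this part of the chain have moved the number little among these three compounds. A similarly small step is therefore expected in this assay, probably toward a higher number, and it may not clear the scatter. The expected change is a 1.8-fold higher number from compound 2 to compound 4 (0.25 log units; within the scatter). Compound 4 is estimated at 80 nM, with an expected range of 35 nM to 190 nM.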

Compound 4, half-maximal inhibitory concentration: 70.4 nM
Compound 4: the middle estimate sits 1.1-fold (0.06 log units) above what was measured; low and high end bracket the measured number.
By their numbers in this assay, from the lowest: compounds 2, 4, 1 and 3 (each within the scatter of the next, the first and the last beyond it).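

In this assay the exchange of 2-(methylsulfanyl)ethyl for hydroxymethyl, which takes out the sulfur and brings in a hydrogen-bond donor, gives a small step (a 1.6-fold higher number from compound 2 to compound 4 (0.20 log units; within the scatter)) and does not clear the usual scatter. Compound 4 also stays within the scatter of the other two compounds (a 1.4-fold lower number from compound 3 to compound 4 (0.14 log units; within the scatter); a 1.2-fold lower number from compound 1 to compound 4 (0.09 log units; within the scatter)), so the short hydroxymethyl chain gives a number in the same narrow band as the carbamoylmethyl, sec-butyl and 2-(methylsulfanyl)ethyl chains. Across these four compounds, a chain ending in a sulfur group, a hydroxy group, a carbamoyl group or only carbon changes the number little, and the one gap beyond the scatter is slight (a 2.1-fold higher number from compound 2 to compound 3 (0.33 log units; beyond the scatter)).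

Still open, going by these compounds, is whether an amine, a carboxylic acid or a much longer chain on this saturated chain carbon would stay in that band or move clearly out of it. Nothing available here offers an explanation for why such different chains give such close numbers.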